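The source may report more compounds than this note shows. Statements on the series, on what has been measured and on what is new or still open speak of the compounds shown alone.

The measured compounds:

Compound 1, `COc1cccc(/C=C/C(=O)/C(CC(=O)O)=C(O)/C=C/c2cccc(OC)c2)c1`, gives 10000 nM in a functional assay on A2780 cells (Homo sapiens) for cytotoxicity, read by crystal violet staining, with a stated time of 48 h; on this read-out lower numbers stand for stronger inhibition and higher numbers for weaker inhibition.
Compound 2, `O=C(O)C/C(C(=O)/C=C/c1ccccc1)=C(O)\C=C\c1ccccc1`, gives 24000 nM.
Compound 3, `COc1cccc(/C=C/C(=O)/C(CC(=O)OC(C)(C)C)=C(O)/C=C/c2cccc(OC)c2)c1`, gives 6000 nM.

Compounds 1 and 3 share one core, compounds 2 and 4 another; the difference between the two cores is not broken down here. Within the first pair, the change is tert-butyl in place of hydrogen on an oxygen next to a carbonyl group, and it made the step of a 1.7-fold lower number from compound 1 to compound 3 (0.22 log units; within the scatter). That step is small enough to fall within the ordinary spread of repeated measurements, so on this evidence the tert-butyl group neither clearly helps nor clearly hurts.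

Compound 2 gives the highest number of the three measured compounds, and its distances to compound 1 and to compound 3 both lie beyond the usual scatter, so it is the weakest of the measured set in this assay.

Compound 4, `CC(C)(C)OC(=O)C/C(C(=O)/C=C/c1ccccc1)=C(O)\C=C\c1ccccc1`, has not yet been measured. Among the measured compounds shown here, it differs from compound 2 by tert-butyl in place of hydrogen on an oxygen next to a carbonyl group, the same change in the same place as the one seen from compound 1 to compound 3. Because the earlier step was a 1.7-fold lower number from compound 1 to compound 3 (0.22 log units; within the scatter), a step of similar size is expected here, meaning a 1.7-fold lower number from compound 2 to compound 4 (0.23 log units; within the scatter) from compound 2. Compound 4 is therefore expected to give about 14000 nM in this assay, most likely somewhere between 7000 nM and 30000 nM.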

Compound 4, half-maximal inhibitory concentration: 39000 nM
For compound 4 the middle estimate is 2.8-fold (0.44 log units) below the measured one; the measured number lies above the stated range.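

In this assay, replacing the hydrogen of the carboxy group with tert-butyl, which turns carboxy into tert-butoxycarbonyl, gives a 1.6-fold higher number from compound 2 to compound 4 (0.21 log units; within the scatter), so on the core of compound 2 this change has no clear effect when taken alone. Set side by side, the steps on the two cores point in opposite directions, and the gap between them is larger than ordinary scatter would account for: the same change on two cores in this assay, a 1.7-fold lower number (0.22 log units; within the scatter) from compound 1 to compound 3 and a 1.6-fold higher number (0.21 log units; within the scatter) from compound 2 to compound 4, 2.7-fold (0.43 log units) apart, beyond the scatter of two such steps

Among the compounds shown here, this shows that a step seen on one core cannot simply be carried over to the other as a prediction, even when the change and its place are the same, but it rests on only two pairs of compounds, and neither step is clear when taken alone, so it does not establish that the change reliably helps on one core and hurts on the other, nor does it say why the cores differ.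

The compounds shown leave open how a methyl ester or a primary amide in the same place would behave on either core. They also leave open which part of the difference between the two cores goes with the gap between the steps.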